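The source may report more compounds than this note shows. Statements on the series, on what has been measured and on what is new or still open speak of the compounds shown alone.

Compound 1 `COC(=O)N(C)CC#CCn1ccnc1` — in a functional assay on the whole organism for agonist activity, with Mus musculus as the target (on this read-out higher numbers stand for an effect only at larger amounts of compound and lower numbers for an effect already at smaller amounts), compound 1 gives 4.5 mg/kg.
Compound 2 `COC(=O)N(C)CC#CCn1cncc1C` — in this assay compound 2 reaches only the limit of the assay, > 100 mg/kg.
Compound 3 `CN(C)C(=O)N(C)CC#CCn1ccnc1` — in this assay compound 3 likewise reaches only the limit of the assay, > 100 mg/kg.

Compound 1 is the only one of the three with a measured number. Compound 2 carries the change (methyl in place of hydrogen on an aromatic carbon), and this single methyl brings an at least 22-fold higher number from compound 1 to compound 2 (1.34 log units; beyond the scatter). Compound 3 carries the change (dimethylamino in place of methoxy on a carbonyl carbon), and that replacement at the carbonyl carbon brings an at least 22-fold higher number from compound 1 to compound 3 (1.34 log units; beyond the scatter). Both of these steps end at the limit of > 100 mg/kg in this assay, at which 2 of the 3 values shown sit, so their true size is not known, only that each is large.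

Compound 4 `Cc1cncn1CC#CCN(C)C(=O)N(C)C` remains to be measured in this assay. It stands to compound 3 as compound 2 stands to compound 1: the change is methyl in place of hydrogen on an aromatic carbon, and the place of the methyl reads word for word the same in both pairs, so this is the same change. Compound 4 therefore combines both changes that, taken singly from compound 1, each gave a large step to the limit. The step from compound 3 is expected to be a step that the limit leaves unreadable from compound 3 to compound 4, resting on the fact that the same methyl gave an at least 22-fold higher number from compound 1 to compound 2 (1.34 log units; beyond the scatter) and that compound 3 already sits at the limit of > 100 mg/kg in this assay, at which 2 of the 3 values shown sit. Compound 4 is accordingly expected to give about 300 mg/kg, somewhere from 100 mg/kg to 1000 mg/kg, and most likely only a limit will be reported.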

Compound 4, dose for half-maximal effect: > 100 mg/kg
Compound 4: no number, only a limit; the forecaster's own chance of this, stated with the estimate: 95%; the middle value lies beyond the limit too.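

In this assay compound 4 also reaches only a limit, so no new step can be read: the steps from compound 3 and from compound 2 to compound 4 both end at a limit, and their sizes stay unreadable. Compound 2, compound 3 and compound 4 stand at the same point: (the limit of > 100 mg/kg in this assay, at which 3 of the 4 values shown sit). The compounds shown leave open how far these three truly differ, and whether the two changes add up in compound 4.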